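The source may report more compounds than this note shows. Statements on the series, on what has been measured and on what is new or still open speak of the compounds shown alone.

Notes on the series. Compound 3 `Cc1ccc(-c2nn(-c3ccccc3)cc2CNc2ccc(Cl)cc2)cc1` was run in an ADME assay on MDBK cells (Bos taurus) for cytotoxicity, read by MTT assay, with a stated time of 72 h (a higher number here means that more compound is tolerated, a lower number that less compound is tolerated), and gives > 100000 nM, which is a limit of the assay and not a number. Compound 1 `Clc1ccc(NCc2cn(-c3ccccc3)nc2-c2ccc(Cl)cc2)cc1` gives > 100000 nM in this assay, again a limit. Compound 2 `Clc1ccc(NCc2cn(-c3ccccc3)nc2-c2ccc(Br)cc2)cc1` gives > 100000 nM; > 100000 nM (2 entries) in this assay, both entries limits. Because of the limit of > 100000 nM in this assay, at which 2 of the 3 values shown sit, compound 3 cannot be placed against the others, and the step that the two limits leave unreadable from compound 1 to compound 3 has no readable size. Compound 4 `Clc1ccc(NCc2cn(-c3ccccc3)nc2-c2ccccc2)cc1` differs from compound 3 by hydrogen in place of methyl on an aromatic carbon. For the measured compounds named here, the only measured step touching this position is a step that the two limits leave unreadable from compound 1 to compound 3, so nothing sets a direction. In this assay the expected change is a step that the limit leaves unreadable from compound 3 to compound 4, no step beyond the scatter. Compound 4 is estimated at 150000 nM, within 60000 nM to 400000 nM, most likely reported again only as a limit.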

Compound 4, half-maximal cytotoxic concentration: > 100000 nM
Compound 4 was reported as a limit; the forecaster's own chance of this, stated with the estimate: 85%; the middle value is on the limit's open side.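

In this assay compound 4 gives > 100000 nM, which is a limit. No step from compound 4 to compound 3 or compound 1 can be read: the limit of > 100000 nM in this assay, at which 3 of the 4 values shown sit.

The compounds shown leave open whether hydrogen, methyl or chloro at this place makes any difference to tolerance in this assay.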